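Two-compound stability series: acetylsulfanyl replaces cyclohexyl carbamate

The source may report more compounds than this note shows. Statements on the series, on what has been measured and on what is new or still open speak of the compounds shown alone.

Compound 1 `CC(=O)N[C@@H]1CCN(c2cc(C)nn3c(-c4cccs4)c(C)nc23)C1` and compound 2 `COc1ccc(-c2c(C)nc3c(N4CC[C@@H](NC(=O)OC5CCCCC5)C4)cc(C)nn23)cc1OC` share a core and differ in the group on the saturated ring carbon of the five-membered ring. In an ADME assay on microsomes from liver (Homo sapiens) for metabolic stability, read by LC-MS, with NADPH named in the record, with a stated time of 60 min, tested at 1 uM, in the absence of a further agent (a lower number here means that less of the compound is left, a higher number that more of the compound is left), compound 1 gives > 95%, which is a limit of the measurement rather than a number. In this assay compound 2 likewise gives > 95%, again only a limit. Compound 2 therefore stands at the same limit as compound 1, (the limit of > 95% in this assay, at which 2 of the 2 values shown sit), and no order between the two can be read from these values.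

Compound 3 `COc1ccc(-c2c(C)nc3c(N4CC[C@@H](SC(C)=O)C4)cc(C)nn23)cc1OC` is the next structure, not yet measured in this assay. Relative to compound 2 the change is acetylsulfanyl in place of (cyclohexyloxycarbonyl)amino on a saturated ring carbon. For the measured compounds named here, no measured step gives a precedent for this change. A decrease beyond the scatter is expected, so that compound 3 is estimated at 78%, with a range from 45% to 97%. This estimate means an expected step of a number at least 17 percentage points lower from compound 2 to compound 3 (beyond the scatter).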

Compound 3, percent of the compound remaining: > 95%
Compound 3: only a limit was reported; the forecaster's own chance of this, stated with the estimate: 30%; middle value at least 17 percentage points from the limit.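

In this assay compound 3 gives > 95%, which is a limit and not a number. For the compounds shown here, no step from compound 2 to compound 3 can be read, since both sit at one limit: the limit of > 95% in this assay, at which 3 of the 3 values shown sit.

On these data alone, the order of compound 1, compound 2 and compound 3 in this assay stays open, as does any difference between acetylsulfanyl and (cyclohexyloxycarbonyl)amino.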